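A few compounds are considered here, and "the series" means these few. Any claim that something is new, unique, unknown or untested is made for them only; others in the source may bear on it.

In a functional assay on HUVEC cells (Homo sapiens) for inhibition, with a stated time of 4 days; a higher number here means a weaker inhibitor, a lower number a stronger inhibitor:
- compound 1 `CNC(=O)c1ccc(OC)c(/C=C/c2ccc(Cl)cc2)c1`: 190 nM
- compound 2 `COc1ccc(C(=O)N(C)C)cc1/C=C/c1ccc(Cl)cc1`: 2500 nM
- compound 3 `CCNC(=O)c1ccc(OC)c(/C=C/c2ccc(Cl)cc2)c1`: 160 nM

Compound 3, at 160 nM, sits level with compound 1 and far below compound 2. Compound 4 `COc1ccc(C(=O)NC(CO)CO)cc1/C=C/c1ccc(Cl)cc1` alters the group on the amide nitrogen: 2-hydroxy-1-(hydroxymethyl)ethyl in place of ethyl on an amide-type nitrogen. Within the data shown here, two measured steps bear on this. Lengthening that chain from methyl to ethyl gave a 1.2-fold lower number from compound 1 to compound 3 (0.07 log units; within the scatter), whereas replacing the amide hydrogen with methyl gave a 13-fold higher number from compound 1 to compound 2 (1.12 log units; beyond the scatter). Among the measured compounds shown here, compound 4 keeps the amide hydrogen, but no measured compound carries a chain like its new one, so the guess is loose. The expected step in this assay is a 2.2-fold higher number from compound 3 to compound 4 (0.34 log units; beyond the scatter), a modest one towards a higher number. The estimate for compound 4 is 350 nM, with an expected range of 90 nM to 1400 nM.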

Compound 4, half-maximal inhibitory concentration in the HUVEC assay: 1500 nM
For compound 4 the middle estimate is 4.3-fold (0.63 log units) below the measured one, outside the stated range (above it).
By their numbers in the HUVEC assay, from the lowest: compounds 3 and 1 (each within the scatter of the next); then compounds 4 and 2 (each within the scatter of the next).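

In the HUVEC assay, keeping the amide hydrogen did not by itself hold the number low at this amide-type nitrogen: 2-hydroxy-1-(hydroxymethyl)ethyl gave a 9.4-fold higher number from compound 3 to compound 4 (0.97 log units; beyond the scatter) and a 7.9-fold higher number from compound 1 to compound 4 (0.90 log units; beyond the scatter), although going from methyl to ethyl had changed little. Also in the HUVEC assay, the comparison with the dimethylamino amide gives a 1.7-fold lower number from compound 2 to compound 4 (0.22 log units; within the scatter), so those two cannot be told apart. In a physicochemical assay for solubility, read by HPLC, in simulated intestinal fluid, with a stated time of 2 h, tested at 10 mM (on this read-out higher numbers stand for higher solubility and lower numbers for lower solubility), compound 3 gives 9 ug/mL and compound 4 gives 251 ug/mL. The price in the HUVEC assay came with a gain in the physicochemical assay: the measured solubility of compound 3, 9 ug/mL, and of compound 4, 251 ug/mL, a 28-fold higher number (1.45 log units; beyond the scatter)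

On these data alone, what remains open is whether the hydroxyl groups or the branching of the chain account for the weaker inhibition. A 2-hydroxyethyl or an isopropyl group on this nitrogen would separate the two.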